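Methoxy for methyl on the aryl ketone of compound 3

The compounds below may be only part of what the source reports. "The series", "measured", "known", "first", "only" and "open" are said of these compounds alone.

Compound 3 `COc1ccc(-c2cc(/C=C/C(=O)c3ccc(C)c(C)c3)nc3cc(-c4ccccc4)nn23)cc1OC` is one of three chalcone-type analogues on a shared core measured in an ADME assay on HEK293 cells (Homo sapiens) for antiproliferative activity, read by MTT assay, with a stated time of 24 h; on this read-out lower numbers stand for stronger inhibition and higher numbers for weaker inhibition. In this assay compound 3 gives 46200 nM, a number within the scatter of both compound 1 `COc1ccc(-c2cc(/C=C/C(=O)c3cc(OC)c(OC)c(OC)c3)nc3cc(-c4ccccc4)nn23)cc1OC`, which gives 35000 nM, and compound 2 `COc1ccc(-c2cc(/C=C/C(=O)c3ccc(OC)c(OC)c3)nc3cc(-c4ccccc4)nn23)cc1`, which gives 48500 nM. Within the data shown here, the one step that bears on the aryl ketone, a 1.3-fold higher number from compound 1 to compound 3 (0.12 log units; within the scatter), was itself within the scatter. Compound 4 `COc1ccc(C(=O)/C=C/c2cc(-c3ccc(OC)c(OC)c3)n3nc(-c4ccccc4)cc3n2)cc1OC` carries 3,4-dimethoxyphenyl in place of 3,4-dimethylphenyl on a carbonyl carbon. Since the trimethoxy-to-dimethyl exchange moved nothing in this assay, the reverse-direction change toward a methoxylated ring is expected to give no step beyond the scatter either, a 1.1-fold lower number from compound 3 to compound 4 (0.04 log units; within the scatter). Compound 4 is therefore estimated at 42000 nM, with a range from 20000 nM to 90000 nM.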

Compound 4, half-maximal inhibitory concentration: 32500 nM
Estimate against measurement, compound 4: 1.3-fold (0.11 log units) above; the measured number falls inside the stated range.
By their numbers in this assay, from the lowest: compounds 4, 1, 3 and 2 (each within the scatter of the next).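

In this assay, 3,4-dimethoxyphenyl in place of 3,4-dimethylphenyl on the carbonyl carbon gives a 1.4-fold lower number from compound 3 to compound 4 (0.15 log units; within the scatter), so a second methyl-to-methoxy comparison at this position also shows no readable change. Single methoxy changes on an aromatic carbon, a 1.5-fold lower number from compound 2 to compound 4 (0.17 log units; within the scatter) and a 1.1-fold lower number from compound 1 to compound 4 (0.03 log units; within the scatter), likewise stay within the scatter. Nothing at hand explains these numbers.

All four compounds carry only methoxy or methyl on the aryl ketone ring. As far as these compounds go, whether an amine or a carboxylic acid there would give a step beyond the scatter stays open.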